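Nitro in Place of Chloro: Estimating Compound 4

A few compounds are considered here, and "the series" means these few. Any claim that something is new, unique, unknown or untested is made for them only; others in the source may bear on it.

Compound 1 `Cc1cc(Nc2cc(N3CCN(C)CC3)nc(Nc3ccc(Cl)cc3)n2)n[nH]1`: 7470 nM
Compound 2 `Cc1cc(Nc2cc(N3CCN(C)CC3)nc(Nc3ccc(C#N)cc3)n2)n[nH]1`: 5780 nM
Compound 3 `COc1ccc(Nc2nc(Nc3cc(C)[nH]n3)cc(N3CCN(C)CC3)n2)cc1`: 18900 nM

In a functional assay on NCI-N87 cells (Homo sapiens) for antiproliferative activity, read by CCK-8 assay, with a stated time of 72 h (on this read-out higher numbers stand for weaker inhibition and lower numbers for stronger inhibition), compound 1 stands second highest of the three numbers; its nearest neighbour is reached by a 1.3-fold lower number from compound 1 to compound 2 (0.11 log units; within the scatter) and its furthest by a 2.5-fold higher number from compound 1 to compound 3 (0.40 log units; beyond the scatter). Compound 4 `Cc1cc(Nc2cc(N3CCN(C)CC3)nc(Nc3ccc([N+](=O)[O-])cc3)n2)n[nH]1` differs from compound 1 by nitro in place of chloro on an aromatic carbon. Both measured exchanges at this aromatic carbon bear on the new one: cyano in place of chloro moved the number within the scatter, methoxy in place of chloro gave a modest rise. Going by the values given here, no step points downward beyond the scatter. The nitro step is expected to be small, with a slight lean toward a weaker number, as a 1.1-fold higher number from compound 1 to compound 4 (0.03 log units; within the scatter). Compound 4 is estimated at 8000 nM, within 3500 nM to 18000 nM.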

Compound 4, half-maximal inhibitory concentration: 3880 nM
For compound 4 the middle estimate is 2.1-fold (0.31 log units) above the measured one; the measured number falls inside the stated range.
By their numbers in this assay, from the lowest: compounds 4, 2 and 1 (each within the scatter of the next); then compound 3.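

In this assay, nitro on this aromatic carbon cannot be told apart from chloro, with a 1.9-fold lower number from compound 1 to compound 4 (0.28 log units; within the scatter), or from cyano, with a 1.5-fold lower number from compound 2 to compound 4 (0.17 log units; within the scatter). Methoxy alone stands apart from the new group, with a 4.9-fold lower number from compound 3 to compound 4 (0.69 log units; beyond the scatter), so it remains the only one of the four groups here whose number is separated from the others. Nothing available explains this difference. The compounds shown leave open how an amine or a carboxylic acid would read on this carbon. They also leave open whether the methoxy gap would hold on another core.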